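A few compounds are considered here, and "the series" means these few. Any claim that something is new, unique, unknown or untested is made for them only; others in the source may bear on it.

Measured compounds in an in vitro ADME assay on microsomes from liver (Homo sapiens) for metabolic stability, tested at 5 uM; a lower number here means that the compound disappears faster, a higher number that the compound lasts longer:
- Compound 1, `CC(C)CCn1nc(-c2cccs2)c(O)c(C2=NS(=O)(=O)c3cc(NS(=O)(=O)C4CC4)ccc3N2)c1=O`: compound 1 gives only a limit of the assay, > 1 h.
- Compound 2, `CC(C)CCn1nc(-c2cccs2)c(O)c(C2=NS(=O)(=O)c3cc(CS(C)(=O)=O)ccc3N2)c1=O`: compound 2 gives 0.467 h.
- Compound 3, `CC(C)(C)CCn1nc(-c2cccs2)c(O)c(C2=NS(=O)(=O)c3cc(NS(C)(=O)=O)ccc3N2)c1=O`: compound 3 gives only a limit of the assay, > 1 h.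

Compound 3 thus sits at the limit of > 1 h in this assay, at which 2 of the 3 values shown sit; where its number lies beyond that limit is not known. Compound 4, `CS(=O)(=O)Nc1ccc2c(c1)S(=O)(=O)N=C(c1c(O)c(-c3cccs3)nn(Cc3ccccc3)c1=O)N2`, is not yet measured. The change from compound 3 to compound 4 is phenyl in place of neopentyl on a saturated chain carbon bound to an aromatic nitrogen; cut one bond further out it reads 3,3-dimethylbutyl to benzyl, on the chain carbon bound to the aromatic nitrogen.

Among the compounds with values here, the only measured step, an at least 2.1-fold lower number from compound 1 to compound 2 (0.33 log units; beyond the scatter), concerns the group on an aromatic carbon of the core and leaves the chain on the aromatic nitrogen untouched, so no measured step bears on the present change, and neither its direction nor its size can be read from the series. With compound 3 known only as a limit, the step to compound 4 is expected to be small: an at least 1.2-fold lower number from compound 3 to compound 4 (0.09 log units; that floor lies within the scatter). For compound 4 the estimate is 0.8 h, between 0.35 h and 1.8 h.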

Compound 4, half-life: > 1 h
Compound 4 gave a limit, no number; the forecaster's own chance of this, stated with the estimate: 40%; middle value at least 1.2-fold (0.09 log units) from the limit.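

In this assay, compound 3 and compound 4 both stand only at the same limit of the assay, so no step between them can be read: the limit of > 1 h in this assay, at which 3 of the 4 values shown sit.

The compounds shown leave open how far compound 3 and compound 4 lie beyond that limit, and so whether 3,3-dimethylbutyl to benzyl changes the half-life at all.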